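This account rests on a few compounds, and the source may have more. Where it says the series, first, only, none or still open, it means among the compounds named here.

Compound 1 `COc1cccc(NC(=O)CSc2nc(Nc3ccccc3)c3ccccc3n2)c1`: 19400 nM
Compound 2 `O=C(CSc1nc(Nc2ccccc2)c2ccccc2n1)Nc1ccc(Br)cc1`: 10600 nM

Two compounds carry a number in a functional assay on NCI-H1975 cells (Homo sapiens) for inhibition, read by MTT assay, with a stated time of 72 h; on this read-out lower numbers stand for stronger inhibition and higher numbers for weaker inhibition. Compound 1 `COc1cccc(NC(=O)CSc2nc(Nc3ccccc3)c3ccccc3n2)c1` gives 19400 nM in this assay, and compound 2 `O=C(CSc1nc(Nc2ccccc2)c2ccccc2n1)Nc1ccc(Br)cc1` gives 10600 nM. For the measured compounds named here, the only measured step, a 1.8-fold lower number from compound 1 to compound 2 (0.26 log units; within the scatter), stays within the scatter, so compound 2 and compound 1 cannot be separated on these numbers.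

Compound 3 `O=C(CSc1nc(Nc2ccccc2)c2ccccc2n1)Nc1ccc(C(F)(F)F)cc1` has not yet been tested. It differs from compound 2 by trifluoromethyl in place of bromo on an aromatic carbon. Going by the values given here, no measured step exchanges bromo for trifluoromethyl; the one step known, a 1.8-fold lower number from compound 1 to compound 2 (0.26 log units; within the scatter), alters the same amide-bound phenyl and did not move the number beyond the scatter. With only that to rest on, compound 3 is expected to give a number close to compound 2 in this assay, a step of about a 1.2-fold lower number from compound 2 to compound 3 (0.07 log units; within the scatter) that is not expected to pass the scatter. The estimate for compound 3 is 9000 nM, with a range from 3500 nM to 25000 nM.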

Compound 3, half-maximal inhibitory concentration: 11700 nM
Compound 3: middle estimate off by 1.3-fold (0.11 log units), on the low side; low and high end bracket the measured number.
By their numbers in this assay, from the lowest: compounds 2, 3 and 1 (each within the scatter of the next).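

In this assay, trifluoromethyl in place of bromo on an aromatic carbon para to a large group gives a 1.1-fold higher number from compound 2 to compound 3 (0.04 log units; within the scatter) and leaves compound 2 and compound 3 inseparable on these numbers. The exchange of the whole amide-bound aryl group, 4-(trifluoromethyl)phenyl in place of 3-methoxyphenyl, gives a 1.7-fold lower number from compound 1 to compound 3 (0.22 log units; within the scatter) and so also stays within the scatter, as the change to 4-bromophenyl did. No measurement at hand accounts for these results.

The compounds leave open whether any group on this phenyl ring, such as an amine or a carboxylic acid, would move the number beyond the scatter. They also leave open how the number responds to changes in the shared core or in the chain linking it to the amide, which all three compounds carry unchanged.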